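This account rests on a few compounds, and the source may have more. Where it says the series, first, only, none or still open, it means among the compounds named here.

Measured so far in a functional assay on HT-29 cells (Homo sapiens) for antiproliferative activity, read by sulforhodamine B assay, with a stated time of 48 h; a lower number here means a stronger inhibitor, a higher number a weaker inhibitor:

- compound 1 `O=C1NCCN1c1ccc(S(=O)(=O)Nc2ccc(C3CCCCC3)cc2)cc1`: > 1000 nM, a limit of the assay and not a number
- compound 2 `Cc1cccc(NS(=O)(=O)c2ccc(N3CCNC3=O)cc2)c1`: 110 nM
- compound 3 `CCCCc1ccc(NS(=O)(=O)c2ccc(N3CCNC3=O)cc2)cc1`: 610 nM

Of the two exact numbers in this assay, the higher belongs to compound 3, at 610 nM. The lower belongs to compound 2, at 110 nM, and that gap lies beyond the usual scatter.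

Compound 4 `CCc1ccc(NS(=O)(=O)c2ccc(N3CCNC3=O)cc2)cc1` trims the butyl of compound 3 to ethyl, with hydrogen in place of ethyl on a saturated chain carbon, two bonds along the chain from an aromatic carbon.

Within the data shown here, only one measured step changes this same group: an at least 1.6-fold lower number from compound 1 to compound 3 (0.21 log units; that floor lies within the scatter). It starts from a limit, so it gives no firm size and only a weak direction. Compound 2 carries the shorter methyl and gives 110 nM, but it is not a one-place change from compound 3, so it is only a loose guide.

A modest move towards stronger inhibition is therefore expected, and the estimated change is a 2.4-fold lower number from compound 3 to compound 4 (0.39 log units; beyond the scatter). Compound 4 is estimated at 250 nM, within an expected range of 90 nM to 700 nM.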

Compound 4, half-maximal inhibitory concentration: 660 nM
Estimate against measurement, compound 4: 2.6-fold (0.42 log units) below, within the range that was stated.
By their numbers in this assay, from the lowest: compound 2; then compounds 3 and 4 (each within the scatter of the next). At a limit, above all of these: compound 1.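

In this assay, the change from butyl to ethyl gives a 1.1-fold higher number from compound 3 to compound 4 (0.03 log units; within the scatter), so this pair shows no measurable effect of removing those two chain carbons. The 4-ethylphenyl of compound 4 also does not match the 3-methylphenyl of compound 2, as a 6.0-fold higher number from compound 2 to compound 4 (0.78 log units; beyond the scatter) shows, so a shorter chain alone did not reproduce the lower number of compound 2. Compound 1 stands at a limit of the assay and not a number, so an at least 1.5-fold lower number from compound 1 to compound 4 (0.18 log units; that floor lies within the scatter) gives only a floor and no firm size: the limit of > 1000 nM in this assay, at which 1 of the 4 values shown sits.

Going by these compounds, whether a propyl chain, or a chain carrying an amine, would fall in line with butyl and ethyl stays open. Also open, on these data alone, is whether compound 2 owes its lower number to the methyl group itself or to where that group sits.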